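One Fluorine Added, Tolerance on Vero Cells Awaited

The source may hold more compounds than are shown below. What is called first, only, known or untested is meant among the compounds shown, and "the series" means these compounds.

Measured so far:
- Compound 1 `O=C(O)c1cccc(-c2ccc(/C=C3\S/C(=N\c4ccc(F)cc4)N(c4ccc(F)cc4)C3=O)s2)c1` in an ADME assay on Vero cells (Chlorocebus sabaeus) for cytotoxicity (a higher number here means that more compound is tolerated, a lower number that less compound is tolerated), gives > 200000 nM, which is a limit of the assay and not a number.
- Compound 2 `O=C(O)c1cccc(-c2ccc(/C=C3\S/C(=N\c4ccccc4)N(c4ccc(F)cc4)C3=O)s2)c1` gives > 200000 nM, again a limit.
- Compound 3 `O=C(O)c1cccc(-c2ccc(/C=C3\S/C(=N\c4ccc(Cl)cc4)N(c4ccccn4)C3=O)o2)c1` gives > 200000 nM, again a limit.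

All three values sit at the limit of > 200000 nM in this assay, at which 3 of the 3 values shown sit, so the measurements do not tell the three apart. The change from compound 2 to compound 1 is fluoro in place of hydrogen on an aromatic carbon; the step that the two limits leave unreadable from compound 2 to compound 1 has two limits at its ends and so its size cannot be read.

Compound 4 `O=C(O)c1cccc(-c2ccc(/C=C3\S/C(=N\c4ccc(Cl)cc4)N(c4ncccc4F)C3=O)o2)c1` has not been measured. It differs from compound 3 by fluoro in place of hydrogen on an aromatic carbon. This is the same kind of change as from compound 2 to compound 1, but the surroundings differ: there the fluoro enters a six-membered aromatic ring of carbon only, para to a large group; here it enters a six-membered aromatic ring with 1 nitrogen, ortho to a large group, two atoms from the ring nitrogen. How the cores of compound 2 and compound 3 differ is not broken down here.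

The step from compound 3 to compound 4 is expected to be flat, a number no higher from compound 3 to compound 4 (the limit leaves the size open), resting on the earlier step that the two limits leave unreadable from compound 2 to compound 1 and on the fact that compound 3 already sits at the limit of > 200000 nM in this assay, at which 3 of the 3 values shown sit. Compound 4 is therefore estimated at 200000 nM, most likely reported as a limit once more.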

Compound 4, half-maximal cytotoxic concentration: > 200000 nM
Compound 4 gave a limit, no number (the forecaster's own chance of this, stated with the estimate: 85%); the middle value lies on the limit itself.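

In this assay, compound 3 and compound 4 both end at a limit of the assay and not at a number, so the step between them cannot be read: the limit of > 200000 nM in this assay, at which 4 of the 4 values shown sit.

The compounds shown leave open at what concentration any of them becomes toxic to the cells, and whether adding a fluoro changes that concentration at all.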